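The compounds below may be only part of what the source reports. "The series", "measured", "known", "first", "only" and "open" are said of these compounds alone.

Measured so far:
compound 1, `Cc1ccc(-c2nc3c(c(C)nn3-c3ccccc3)c(-c3ccccc3O)c2C#N)cc1`, 26000 nM
compound 2, `Cc1ccccc1-c1nc2c(c(C)nn2-c2ccccc2)c(-c2ccccc2O)c1C#N`, 21000 nM

Both numbers come from a physicochemical assay for solubility, read by spectrophotometry, in phosphate buffer, with a stated time of 18 h, at pH 7.4; a lower number here means a less soluble compound, a higher number a more soluble compound. Compound 2 sits alongside compound 1: the step of a 1.2-fold lower number from compound 1 to compound 2 (0.09 log units; within the scatter) is within the scatter, so the two values cannot be told apart on this pair alone. Compound 3, `CCCc1ccc(-c2nc3c(c(C)nn3-c3ccccc3)c(-c3ccccc3O)c2C#N)cc1`, is not yet measured in this assay. It differs from compound 2 by 4-propylphenyl in place of 2-methylphenyl on an aromatic carbon.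

Within the data shown here, only one measured step bears on this change, a 1.2-fold lower number from compound 1 to compound 2 (0.09 log units; within the scatter), and it covers just the move of a methyl group between positions on the phenyl ring; no measured pair covers a propyl chain in place of a methyl group. Compound 1 carries the same 4-substituted pattern that compound 3 has, so compound 1 is the closer anchor for the pattern, with compound 2 the formal starting point.

Among the measured compounds shown here, with no measured step for the added chain, the estimate for compound 3 is set a little below compound 2, as a step of a 1.8-fold lower number from compound 2 to compound 3 (0.24 log units; within the scatter) that is expected to land near the edge of the scatter. Compound 3 is therefore expected to give about 12000 nM, with a range from 5000 nM to 30000 nM.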

Compound 3, solubility: 6500 nM
The estimate for compound 3 lay 1.8-fold (0.27 log units) above the measured number; low and high end bracket the measured number.
By their numbers in this assay, from the lowest: compound 3; then compounds 2 and 1 (each within the scatter of the next).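

In this assay, among these compounds, this aryl position, next to the ring nitrogen and ortho to a cyano group, now gives a step beyond the scatter, a 3.2-fold lower number from compound 2 to compound 3 (0.51 log units; beyond the scatter), for 4-propylphenyl in place of 2-methylphenyl, whereas moving the methyl group around the phenyl ring gave no step that could be told from the scatter. The pair that keeps the 4-substituted pattern fixed and differs only in the chain, with ethyl in place of hydrogen on the saturated carbon, gives a 4.0-fold lower number from compound 1 to compound 3 (0.60 log units; beyond the scatter), so the lower number goes with the propyl chain in both pairs, though both steps are modest. No measurement among the data shown explains this change.

As far as these compounds go, whether the number falls further with a butyl or longer chain, or where an ethyl group would fall relative to methyl and propyl, remains open, as does the reading for a 2-propylphenyl group, which would separate chain length from the chain's place on the phenyl ring. Also open, from the compounds shown here alone, is what an amine or a carboxylic acid at the end of the chain would do to the number in this assay on this shared core.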